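The source may report more compounds than this note shows. Statements on the series, on what has been measured and on what is new or still open speak of the compounds shown alone.

Among the compounds with values here, in a functional assay on the whole organism with Mus musculus as the target, in the rotarod test (on this read-out lower numbers stand for an effect already at smaller amounts and higher numbers for an effect only at larger amounts of compound), compound 3 `CCN(CC)CC(=O)NCC(=O)N(C)c1ccc(Cl)cc1C(=O)c1ccccc1Cl` gives 34 mg/kg, the only number among the three values shown. Compound 1 `CC(C)C(=O)NCC(=O)N(C)c1ccc(Cl)cc1C(=O)c1ccccc1Cl` gives only a limit in this assay, > 100 mg/kg. Compound 2 `CC(=O)NCC(=O)Nc1ccc(Cl)cc1C(=O)c1ccccc1Cl` likewise gives only a limit, > 100 mg/kg. Compound 4 `CC(=O)NCC(=O)N(C)c1ccc(Cl)cc1C(=O)c1ccccc1Cl` differs from compound 3 by hydrogen in place of diethylamino on a saturated chain carbon bound to a carbonyl carbon. The measured step of an at least 2.9-fold lower number from compound 1 to compound 3 (0.46 log units; beyond the scatter) bears on this change: entry of the diethylamino group carried the value from the limit to a number, and compound 4 removes that same group. Because the limit of > 100 mg/kg in this assay, at which 2 of the 3 values shown sit, is where both compounds lacking it sit, a step upward, beyond the scatter, is expected for compound 4 in this assay, a 4.4-fold higher number from compound 3 to compound 4 (0.64 log units; beyond the scatter). Compound 4 is therefore estimated at 150 mg/kg, between 60 mg/kg and 400 mg/kg, most likely reported only as a limit.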

Compound 4, dose for half-maximal effect: 58 mg/kg
The estimate for compound 4 lay 2.6-fold (0.41 log units) above the measured number; the measured number lies below the stated range.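

In this assay, the step of a 1.7-fold higher number from compound 3 to compound 4 (0.23 log units; within the scatter) shows that on this saturated chain carbon bound to a carbonyl carbon, the number does not depend on diethylamino: the two values lie within the scatter. Neither an at least 1.7-fold lower number from compound 1 to compound 4 (0.23 log units; that floor lies within the scatter) nor an at least 1.7-fold lower number from compound 2 to compound 4 (0.23 log units; that floor lies within the scatter) goes beyond a floor within the scatter, so neither methyl change can be called a gain. Compound 1 and compound 2 remain limits of the assay: the limit of > 100 mg/kg in this assay, at which 2 of the 4 values shown sit.

Going by these compounds, whether a morpholine, a dimethylamino group or a longer chain on this carbon would move the number beyond the scatter stays open.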